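Replacing a hydroxyphenyl-bearing linker with bromophenyl

The source may hold more compounds than are shown below. What is called first, only, known or untested is meant among the compounds shown, and "the series" means these compounds.

Compound 1 `COc1cc(NC(C)CCCNC(=O)NNC(=O)Nc2cccc(C(F)(F)F)c2)c2ncccc2c1`: 6900 nM
Compound 2 `COc1cc(NC(C)CCCNC(=O)NNC(=O)Nc2ccc(O)cc2)c2ncccc2c1`: 111000 nM
Compound 3 `COc1cc(NC(C)CCCNC(=O)NNC(=O)Nc2ccc(C(F)(F)F)cc2)c2ncccc2c1`: 18000 nM

In a functional assay on CCRF-CEM cells (Homo sapiens) for inhibition, read by MTT assay, with a stated time of 72 h (on this read-out higher numbers stand for weaker inhibition and lower numbers for stronger inhibition), compound 2 gives the highest number of the three, with compound 3 nearest and compound 1 furthest from it. Going by these compounds, compound 4 `COc1cc(NC(C)CCCNC(=O)Nc2ccc(Br)cc2)c2ncccc2c1` is untested; it differs from compound 2 in one place: 4-bromophenyl in place of ((4-hydroxyphenyl)carbamoyl)amino on an amide-type nitrogen. Within the data shown here, no measured step removes the carbamoylamino link itself, so the closest guide is a 6.2-fold lower number from compound 2 to compound 3 (0.79 log units; beyond the scatter), where a halogen-like substituent in place of hydroxy on the aromatic carbon lowered the number, and a 16-fold higher number from compound 1 to compound 2 (1.21 log units; beyond the scatter), which shows the hydroxy compound as the weakest. A lower number is therefore expected for compound 4, of modest size, a 7.4-fold lower number from compound 2 to compound 4 (0.87 log units; beyond the scatter). The estimate for compound 4 is 15000 nM, between 4000 nM and 60000 nM.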

Compound 4, half-maximal inhibitory concentration: 23000 nM
Beside the measured number, compound 4's estimate is 1.5-fold (0.19 log units) below it, and the stated range covers the measured number.
By their numbers in this assay, from the lowest: compound 1; then compounds 3 and 4 (each within the scatter of the next); then compound 2.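

In this assay, among these compounds, a 4.8-fold lower number from compound 2 to compound 4 (0.68 log units; beyond the scatter) shows that this amide-type nitrogen can lose the whole ((4-hydroxyphenyl)carbamoyl)amino group, carbamoylamino link included, without the number rising, whereas the earlier compounds all kept that link and varied only the aromatic ring's substituent. The change removes the link and the hydroxy together, so this one step cannot assign the drop to either. No measurement shown explains the step. Going by these compounds, it remains open whether the bromine matters at all, and how a plain phenyl or a 4-aminophenyl group on this nitrogen would read.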